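This account rests on a few compounds, and the source may have more. Where it says the series, first, only, none or still open, it means among the compounds named here.

In a functional assay on A549 cells (Homo sapiens) for antiproliferative activity, read by MTT assay, with a stated time of 48 h (on this read-out higher numbers stand for weaker inhibition and lower numbers for stronger inhibition), compound 1 `Cc1ccc2nc(NC(c3cn(-c4ccccc4)nc3-c3cccc([N+](=O)[O-])c3)c3c(O)ccc4ccccc34)sc2c1` gives 57400 nM. Among the measured compounds shown here, the only other measured compound, compound 2 `Cc1ccc2nc(NC(c3cn(-c4ccccc4)nc3-c3cccc(Cl)c3)c3c(O)ccc4ccccc34)sc2c1`, gives 45400 nM, so these two values lie within the usual scatter of repeat measurements. Compound 3 `COc1ccc2nc(NC(c3cn(-c4ccccc4)nc3-c3cccc([N+](=O)[O-])c3)c3c(O)ccc4ccccc34)sc2c1` has not been measured yet. It keeps the core of compound 1 but carries 6-methoxy-1,3-benzothiazol-2-yl in place of 6-methyl-1,3-benzothiazol-2-yl: methoxy in place of methyl on an aromatic carbon. For the measured compounds named here, the only measured step, a 1.3-fold lower number from compound 1 to compound 2 (0.10 log units; within the scatter), comes from chloro in place of nitro on an aromatic carbon. Going by the values given here, that is a different place in the molecule, so it offers only indirect guidance, and no measurement yet tests the methyl-to-methoxy swap itself. With so little evidence, no shift beyond the scatter is expected in this assay, though the range must stay wide. The expected step, a 1.2-fold lower number from compound 1 to compound 3 (0.08 log units; within the scatter), is correspondingly small. For compound 3, the estimated value is 48000 nM, with an expected range from 20000 nM to 100000 nM.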

Compound 3, half-maximal inhibitory concentration: 52200 nM
Estimate against measurement, compound 3: 1.1-fold (0.04 log units) below, and the stated range covers the measured number.
By their numbers in this assay, from the lowest: compounds 2, 3 and 1 (each within the scatter of the next).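

In this assay, the first direct test at this position gives a 1.1-fold lower number from compound 1 to compound 3 (0.04 log units; within the scatter) and so shows no measurable effect of placing methoxy on this aromatic carbon in place of methyl. The methoxy is the larger of the two groups and brings a hydrogen-bond acceptor that the methyl lacks, yet neither difference separates the two numbers on this read-out. Nothing measured here offers an explanation for this flat result.

The compounds shown leave open whether a different kind of group on this aromatic carbon, such as an amine, a carboxylic acid or a longer chain like butoxy, would move the number beyond the scatter. They also leave open whether methoxy would behave the same way with the chloro of compound 2 in place of the nitro.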